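The compounds below may be only part of what the source reports. "The series", "measured", "known", "first", "only" and "open" are said of these compounds alone.

Three compounds have been measured in an assay on cells with melanin-concentrating hormone receptor 1 (Homo sapiens) as the target, read by radioligand binding; on this read-out lower numbers stand for stronger inhibition and higher numbers for weaker inhibition:

Compound 1, `Nc1ccc2cccc(OC3CCCCC3)c2n1`: 361 nM
Compound 2, `CCCCOc1cccc2ccc(N)nc12`: 789 nM
Compound 3, `CSCCOc1cccc2ccc(N)nc12`: > 2000 nM, a limit of the assay rather than a number

Compound 1 holds the lowest of the two numbers on hand. Its nearest neighbour is compound 2, reached by a 2.2-fold higher number from compound 1 to compound 2 (0.34 log units; beyond the scatter). Compound 3 sits at the limit of > 2000 nM in this assay, at which 1 of the 3 values shown sits. From compound 1 that is an at least 5.5-fold higher number from compound 1 to compound 3 (0.74 log units; beyond the scatter), and from compound 2 it is an at least 2.5-fold higher number from compound 2 to compound 3 (0.40 log units; beyond the scatter).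

The next compound is compound 4, `CC(C)(C)CCOc1cccc2ccc(N)nc12`. It differs from compound 1 by 3,3-dimethylbutyl in place of cyclohexyl on an oxygen on an aromatic ring.

Going by the values given here, only one measured step bears on this change: the one from compound 1 to compound 2, where a chain on the same oxygen also took the place of the cyclohexyl and gave a modest rise in the number. The step to compound 3 involves a different kind of chain and sits at a limit, so it offers less guidance. The branched 3,3-dimethylbutyl chain matches the cyclohexyl in the count of carbons, so a step of similar direction but perhaps smaller size than that to compound 2 is expected, a 1.5-fold higher number from compound 1 to compound 4 (0.18 log units; within the scatter). Compound 4 is therefore estimated at 550 nM, within a range of 220 nM to 1400 nM.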

Compound 4, half-maximal inhibitory concentration: 201 nM
Beside the measured number, compound 4's estimate is 2.7-fold (0.44 log units) above it; the whole stated range lies above it.
By their numbers in this assay, from the lowest: compounds 4 and 1 (each within the scatter of the next); then compound 2. At a limit, above all of these: compound 3.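

In this assay, the ring on the oxygen turns out not to be required: 3,3-dimethylbutyl has no ring but the same 6 heavy atoms as cyclohexyl, and the change gives a 1.8-fold lower number from compound 1 to compound 4 (0.25 log units; within the scatter), so the two compounds cannot be told apart. An open chain on this oxygen is therefore not in itself what separated compound 2 from compound 1, since tert-butyl in place of ethyl at the end of the chain gives a 3.9-fold lower number from compound 2 to compound 4 (0.59 log units; beyond the scatter), which shows that the chain end matters at this place. Tert-butyl in place of methylsulfanyl gives an at least 9.9-fold lower number from compound 3 to compound 4 (0.99 log units; beyond the scatter), but this step rests on a limit for compound 3 and not on a number: the limit of > 2000 nM in this assay, at which 1 of the 4 values shown sits.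

The compounds shown leave open how a longer chain or a chain ending in an amine or a carboxylic acid would read on the same oxygen. They also leave open whether a cyclopentyl or a phenyl group would match cyclohexyl and 3,3-dimethylbutyl, and so how much room for change this place allows.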